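Swapping a methylphenyl for a hydroxyphenyl on the ring core

A few compounds are considered here, and "the series" means these few. Any claim that something is new, unique, unknown or untested is made for them only; others in the source may bear on it.

Compound 3, `COc1cc(/C=C/C(=O)C2=C(/C=C/c3ccc(O)c(OC)c3)NC(=S)NC2c2ccc(C)cc2)ccc1O`, was tested in a functional assay, with a stated time of 20 min, tested at 10 uM (on this read-out higher numbers stand for a stronger effect at the one concentration tested and lower numbers for a weaker effect), and gave 19.9%. Compound 2, `COc1cc(/C=C/C(=O)C2=C(/C=C/c3ccc(O)c(OC)c3)NC(=S)NC2c2ccccc2)ccc1O`, gave 22%, a number that lies within the scatter of the reading for compound 3. Within the data shown here, compound 1, `COc1cc(/C=C/C(=O)C2=C(/C=C/c3ccc(O)c(OC)c3)NC(=O)NC2c2ccc(N(C)C)cc2)ccc1O`, gave 69.9%, which is well beyond the scatter above compound 3; compound 1 differs from compound 3 in more than one place, so no single step can be drawn from it.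

Compound 4, `COc1cc(/C=C/C(=O)C2=C(/C=C/c3ccc(O)c(OC)c3)NC(=S)NC2c2ccccc2O)ccc1O`, has not yet been measured. It differs from compound 3 in one place: 2-hydroxyphenyl in place of 4-methylphenyl on a saturated ring carbon.

Among the measured compounds shown here, the only measured step that bears on this position is the one from compound 2 to compound 3, a change on the same phenyl ring, which moved the read-out by a number 2.1 percentage points lower from compound 2 to compound 3 (within the scatter). For the measured compounds named here, that step was within the scatter, and no measured pair shows the effect of a hydroxyl at this place. The expected step from compound 3 to compound 4 is therefore a number 2.1 percentage points higher from compound 3 to compound 4 (within the scatter), none beyond the scatter. Compound 4 is estimated at 22%, in the range 8% to 40%.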

Compound 4, a percentage reported as activity, at one concentration (the size of the read-out at that concentration, not a potency): 70.8%
Estimate against measurement, compound 4: 48.8 percentage points below; the measured number lies above the stated range.
By their numbers in this assay, from the lowest: compounds 3 and 2 (each within the scatter of the next); then compounds 1 and 4 (each within the scatter of the next).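

The aryl group on the saturated ring carbon turns out to matter far more than the methyl step suggested: in this assay the move to 2-hydroxyphenyl gives a number 50.9 percentage points higher from compound 3 to compound 4 (beyond the scatter) and adding just the hydroxy to the plain phenyl gives a number 48.8 percentage points higher from compound 2 to compound 4 (beyond the scatter). Methyl in place of hydrogen on this ring stayed within the scatter, whereas hydroxy in place of hydrogen went far beyond it, so the two ring changes are not interchangeable. Nothing available explains this rise.

The methyl and the hydroxy also sit at different ring positions, so these compounds cannot separate the effect of the group from the effect of its position. From the compounds shown here alone, whether a methoxy group or an amine on this ring would produce a similar rise remains open.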